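Compound 4 of the cyanoguanidine series: phenyl for furan-2-yl

A few compounds are considered here, and "the series" means these few. Any claim that something is new, unique, unknown or untested is made for them only; others in the source may bear on it.

Of the compounds shown here, three have been measured in an assay on HeLa cells for displacement of a labelled ligand from adenosine receptor A3 (Homo sapiens), with a stated time of 180 min, tested at 1 uM; a lower number here means less inhibition, a higher number more inhibition at the concentration tested (going by the name of the read-out). Compound 1 `CCOC(=O)C1=C(C)N/C(=N\C#N)NC1c1ccco1` gives 20%, which places it second highest of the three. Compound 2 `CC1=C(C(=O)OC(C)C)C(c2ccco2)N/C(=N/C#N)N1` gives 4%, and compound 3 `CC1=C(C(=O)OC(C)C)C(c2ccoc2)N/C(=N/C#N)N1` gives 41%. The step of a number 16 percentage points lower from compound 1 to compound 2 (beyond the scatter) follows from a methyl in place of hydrogen on a saturated chain carbon bound to an oxygen next to a carbonyl group and a saturated chain carbon. The step of a number 37 percentage points higher from compound 2 to compound 3 (beyond the scatter) follows from furan-3-yl in place of furan-2-yl on a saturated ring carbon.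

Compound 4 `CCOC(=O)C1=C(C)N/C(=N\C#N)NC1c1ccccc1` differs from compound 1 by phenyl in place of furan-2-yl on a saturated ring carbon. Within the data shown here, no measured step makes this same exchange. The step from compound 2 to compound 3 touches the same saturated ring carbon and shows that the aryl group there can shift the read-out strongly, yet it replaces one furan isomer by another rather than by phenyl, so its size cannot be carried over. The ester step from compound 1 to compound 2 concerns a different place. With only indirect guidance, the expected step of a number 2 percentage points higher from compound 1 to compound 4 (within the scatter) is modest, and compound 4 is estimated at 22%, within a range from 4% to 45%.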

Compound 4, a percentage reported as inhibition, at one concentration (the size of the read-out at that concentration, not a potency): 13%
Compound 4: the middle estimate sits 9 percentage points above what was measured, and the stated range covers the measured number.
By their numbers in this assay, from the lowest: compounds 2, 4 and 1 (each within the scatter of the next, the first and the last beyond it); then compound 3.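

In this assay, the exchange of furan-2-yl for phenyl on the saturated ring carbon gives a number 7 percentage points lower from compound 1 to compound 4 (within the scatter) and so adds a six-membered aromatic ring of carbon only to what this position is seen to accept, with the ring oxygen of furan-2-yl gone and the read-out staying within the scatter of that of the furan compound. The earlier step at the same carbon, a number 37 percentage points higher from compound 2 to compound 3 (beyond the scatter), lay beyond the scatter, so the two steps together show that an exchange of the aromatic group here does not always move the read-out by a clear margin, even though one furan isomer for the other did so on the ester of compound 2. Nothing at hand bears on the reason for this result.

The compounds shown leave open whether phenyl would read the same on the ester of compound 2, since the effect of this exchange is seen on the ethoxycarbonyl compound alone. They also leave open whether a phenyl carrying a methoxy group, or a pyridine ring, on this carbon would reach the level of compound 3 at 41% or stay with the lower numbers.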